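The source may report more compounds than this note shows. Statements on the series, on what has been measured and on what is new or still open speak of the compounds shown alone.

Going by the values given here, compound 3 `COc1cc(C(=O)/C=C/c2cn(-c3ccccc3)nc2-c2cccnc2)cc(OC)c1OC` gives 14500 nM in a functional assay on MCF7 cells (Homo sapiens) for inhibition, read by sulforhodamine B assay, with a stated time of 72 h (on this read-out lower numbers stand for stronger inhibition and higher numbers for weaker inhibition), the highest of the three numbers so far. Compound 1 `O=C(/C=C/c1cn(-c2ccccc2)nc1-c1cccnc1)c1ccccn1` gives 4200 nM and compound 2 `O=C(/C=C/c1cn(-c2ccccc2)nc1-c1cccnc1)c1c[nH]c2ccccc12` gives 2600 nM; both stand beyond the scatter from compound 3. Compound 4 `COc1ccc(C(=O)/C=C/c2cn(-c3ccccc3)nc2-c2cccnc2)cc1OC` differs from compound 3 by hydrogen in place of methoxy on an aromatic carbon. Among the compounds with values here, the only measured step, a 1.6-fold lower number from compound 1 to compound 2 (0.21 log units; within the scatter), alters the group on the carbonyl carbon and not the aryl ring that changes here, so it does not bear on this change directly; it shows only that an exchange of an aromatic group at one end of the shared core moved the number within the scatter. Within the data shown here, no measured pair shows what removing one methoxy group does. Compound 4 is therefore expected to stay close to compound 3, with the step of a 1.5-fold lower number from compound 3 to compound 4 (0.16 log units; within the scatter) not clearly beyond the scatter in either direction. The estimate for compound 4 is 10000 nM, within a range from 3500 nM to 28000 nM.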

Compound 4, half-maximal inhibitory concentration: 1700 nM
Beside the measured number, compound 4's estimate is 5.9-fold (0.77 log units) above it; the whole stated range lies above it.
By their numbers in this assay, from the lowest: compounds 4, 2 and 1 (each within the scatter of the next, the first and the last beyond it); then compound 3.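

In this assay, taking away one methoxy group on this aromatic carbon gives an 8.5-fold lower number from compound 3 to compound 4 (0.93 log units; beyond the scatter), so this single change on the aryl ring moves the number beyond the scatter, which the earlier step at the carbonyl carbon, an exchange of one aromatic group for another, could not show. With 3,4-dimethoxyphenyl on the carbonyl carbon, the number stays within the scatter of the 1H-indol-3-yl compound, at a 1.5-fold lower number from compound 2 to compound 4 (0.18 log units; within the scatter), and lies beyond the scatter of the pyridin-2-yl compound, at a 2.5-fold lower number from compound 1 to compound 4 (0.39 log units; beyond the scatter). Nothing at hand explains why removing this methoxy group has this effect.

Going by these compounds, whether the two remaining methoxy groups count in the same way stays open. So does whether an ethoxy group, a hydroxy group or an amine on this aromatic carbon would give a number nearer that of compound 4 or that of compound 3.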